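A Boronic Acid in Place of Carboxymethoxy

A few compounds are considered here, and "the series" means these few. Any claim that something is new, unique, unknown or untested is made for them only; others in the source may bear on it.

Of the compounds shown here, three with a shared core have been measured in a functional assay on MDA-MB-231 cells (Homo sapiens) for inhibition; on this read-out higher numbers stand for weaker inhibition and lower numbers for stronger inhibition. Compound 1 `O=C(/C=C/c1ccc(F)c(Cl)c1)c1ccc(B(O)O)cc1` gives 8500 nM. Compound 2 `O=C(/C=C/c1ccc(B(O)O)cc1)c1ccc(Cl)c(Cl)c1` gives 8000 nM. Compound 3 `O=C(O)COc1ccc(C(=O)/C=C/c2ccc(Cl)c(Cl)c2)cc1` gives 9000 nM. Compound 3 has the highest of the three numbers, but its nearest neighbour on this scale, compound 1, and its furthest, compound 2, both lie within the scatter of it, so the three values show no ordering that can be trusted.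

The step from compound 3 leads to compound 4 `O=C(/C=C/c1ccc(Cl)c(Cl)c1)c1ccc(B(O)O)cc1`, which is not yet measured in this assay. The change is a group of 3 heavy atoms (1 boron, 2 oxygen; no ring) in place of a group of 5 heavy atoms (2 carbon, 3 oxygen; no ring), on an aromatic carbon: the carboxymethoxy group leaves and a group without a common name enters, on an aromatic carbon of a six-membered aromatic ring of carbon only, para to a large group.

Among the compounds with values here, no step between measured compounds isolates this change, so its size must be guessed from the whole set. Compound 4 is expected to land near the three measured numbers, giving an estimated 8500 nM with a range from 4000 nM to 18000 nM, because compound 1 gives 8500 nM and compound 2 gives 8000 nM with the same entering group present. This estimate means a step of a 1.1-fold lower number from compound 3 to compound 4 (0.02 log units; within the scatter) for compound 4, expected to stay within the scatter.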

Compound 4, half-maximal inhibitory concentration: 9500 nM
Compound 4: the middle estimate sits 1.1-fold (0.05 log units) below what was measured; measured number inside the range.
By their numbers in this assay, from the lowest: compounds 2, 1, 3 and 4 (each within the scatter of the next).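

In this assay, the boronic acid in place of carboxymethoxy, on an aromatic carbon para to a large group, gives a 1.1-fold higher number from compound 3 to compound 4 (0.02 log units; within the scatter). Within the data shown here, this is the one direct comparison of the two groups on an otherwise identical compound, and on this read-out it does not tell them apart, which the earlier compounds, differing in more than one place, could not show. Chloro in place of fluoro on an aromatic carbon, with the boronic acid present, gives a 1.1-fold higher number from compound 1 to compound 4 (0.05 log units; within the scatter), so this second exchange cannot be told apart from the scatter either, and no measurement offers a reason for either result.

The compounds shown leave open whether any group at this position moves the number at all, since both groups compared here give the same reading within the scatter. As far as these compounds go, what a plain hydrogen, an amine, a carboxylic acid set directly on the ring or a longer chain ending in a carboxylic acid would give at this position remains unknown.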